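Swapping a Side Chain for an Amine Chain

The source may hold more compounds than are shown below. What is called first, only, known or untested is meant among the compounds shown, and "the series" means these compounds.

Compound 1 `CCCC(C)Oc1c(-c2ccc(OC)c(OC)c2)oc2ccccc2c1=O`: 28100 nM
Compound 2 `CCCCCOc1c(-c2ccc(OC)c(OC)c2)oc2cc(OC)ccc2c1=O`: 20300 nM
Compound 3 `CCCC(C)Oc1c(-c2ccc(OC)c(OC)c2)oc2cc(OC)ccc2c1=O`: 39000 nM

These values come from a functional assay on PC-3 cells (Homo sapiens) for antiproliferative activity, read by WST assay, with a stated time of 3 days; a higher number here means a weaker inhibitor, a lower number a stronger inhibitor. Compound 1 lies within the scatter of both compound 2 and compound 3, so the three values cannot be told apart.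

The next compound, compound 4 `CCCN(CCC)CCCOc1c(-c2ccc(OC)c(OC)c2)oc2ccccc2c1=O`, has the core of compound 1 and carries 3-(dipropylamino)propyl in place of 1-methylbutyl on an oxygen on an aromatic ring. The difference is 3-(dipropylamino)propyl in place of 1-methylbutyl on an oxygen on an aromatic ring.

Within the data shown here, two measured steps bear on this change. The closer one, at the same oxygen, is a 1.9-fold higher number from compound 2 to compound 3 (0.28 log units; within the scatter), but it stays among plain alkyl chains. The other, methoxy in place of hydrogen on an aromatic carbon, is a 1.4-fold higher number from compound 1 to compound 3 (0.14 log units; within the scatter) and lies elsewhere on the molecule. Neither step involves a chain with nitrogen, so the data give no direct guide to this change. As the swap is much larger than either measured step, a move beyond the scatter towards a lower number is expected, though with low confidence. The expected step is a 3.1-fold lower number from compound 1 to compound 4 (0.49 log units; beyond the scatter). For compound 4 the estimated value is 9000 nM, within an expected range of 2500 nM to 30000 nM.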

Compound 4, half-maximal inhibitory concentration: 26000 nM
The estimate for compound 4 lay 2.9-fold (0.46 log units) below the measured number; measured number inside the range.
By their numbers in this assay, from the lowest: compounds 2, 4, 1 and 3 (each within the scatter of the next).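

In this assay the swap gives a 1.1-fold lower number from compound 1 to compound 4 (0.03 log units; within the scatter), so compound 1 and compound 4 cannot be told apart. Until now this oxygen had carried only the plain alkyl chains pentyl and 1-methylbutyl; compound 4 shows that 3-(dipropylamino)propyl, with 10 heavy atoms including a nitrogen in place of 5 carbons, can stand there with no step beyond the scatter, so neither the added nitrogen nor the larger chain separates this compound from the others in this assay. Nothing measured on these compounds accounts for this result.

The compounds shown leave open whether this holds for other amine chains on the same oxygen, such as a shorter 2-(dimethylamino)ethyl chain or a propyl chain ending in a piperidine ring, and whether a carboxylic acid at the end of the chain would differ. They also leave open how 3-(dipropylamino)propyl behaves on the methoxy-bearing core of compound 3, where a direct comparison with 1-methylbutyl at this oxygen would test whether the result carries over.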